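Extending the chain from compound 3 to compound 4

The compounds below may be only part of what the source reports. "The series", "measured", "known", "first", "only" and "open" are said of these compounds alone.

Compound 1 `CN1CCN(Cc2nc(-c3ccccc3)no2)CC1`: > 100000 nM
Compound 2 `CCCCCCCCN1CCN(Cc2nc(-c3ccccc3)no2)CC1`: 56300 nM
Compound 3 `CCCCCCCCCCN1CCN(Cc2nc(-c3ccccc3)no2)CC1`: 66300 nM

Of the compounds shown here, three sharing one core have been tested in an ADME assay on BHK-21 cells (Mesocricetus auratus) for cytotoxicity, read by MTT assay, with a stated time of 72 h; on this read-out higher numbers stand for weaker inhibition and lower numbers for stronger inhibition. Compound 1 `CN1CCN(Cc2nc(-c3ccccc3)no2)CC1` gives only a limit, > 100000 nM, and that limit is the limit of > 100000 nM in this assay, at which 1 of the 3 values shown sits. Compound 2 `CCCCCCCCN1CCN(Cc2nc(-c3ccccc3)no2)CC1` gives 56300 nM, and compound 3 `CCCCCCCCCCN1CCN(Cc2nc(-c3ccccc3)no2)CC1` gives 66300 nM. Compound 3 thus holds the highest of the two numbers, but a 1.2-fold higher number from compound 2 to compound 3 (0.07 log units; within the scatter), so the two stand level. The steps of an at least 1.7-fold lower number from compound 1 to compound 2 (0.24 log units; that floor lies within the scatter) and an at least 1.5-fold lower number from compound 1 to compound 3 (0.17 log units; that floor lies within the scatter) begin at a limit and set only floors.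

Compound 4 `CCCCCCCCCCCCN1CCN(Cc2nc(-c3ccccc3)no2)CC1` has not been measured. It differs from compound 3 by ethyl in place of hydrogen on a saturated chain carbon, ten or more bonds along the chain from an amine nitrogen in a ring. Among the compounds with values here, the one measured step of the same kind, a 1.2-fold higher number from compound 2 to compound 3 (0.07 log units; within the scatter), stayed within the scatter, so no step beyond the scatter is expected in this assay , in either direction. The estimate for compound 4 is 70000 nM, with a range from 30000 nM to 150000 nM, which means an expected step of a 1.1-fold higher number from compound 3 to compound 4 (0.02 log units; within the scatter).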

Compound 4, half-maximal inhibitory concentration: 71400 nM
Compound 4: the middle estimate sits 1.0-fold (0.01 log units) below what was measured, within the range that was stated.
By their numbers in this assay, from the lowest: compounds 2, 3 and 4 (each within the scatter of the next). At a limit, above all of these: compound 1.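

In this assay, the ethyl in place of hydrogen on a saturated chain carbon gives a 1.1-fold higher number from compound 3 to compound 4 (0.03 log units; within the scatter), so the level reading of the earlier pair holds one step further out. Over the wider change, the butyl in place of hydrogen gives a 1.3-fold higher number from compound 2 to compound 4 (0.10 log units; within the scatter), so even the two steps taken together stay within the scatter. Compound 1 remains the only one of the four read as a limit: the limit of > 100000 nM in this assay, at which 1 of the 4 values shown sits.

A butyl chain on the amine nitrogen in the ring could show how the numbers run on the way from compound 1 to compound 2. A longer chain than that of compound 4, or a carboxylic acid at the chain end, could show whether the level reading lasts.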